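Dropping the cyano from the chain of compound 1

The source may report more compounds than this note shows. Statements on the series, on what has been measured and on what is new or still open speak of the compounds shown alone.

Working notes on a small set of triarylethylene-type analogues sharing one core. Within the data shown here, compound 1 `N#CC/C(=C(/c1ccc(O)cc1)c1ccc(OCCN)cc1)c1ccccc1` is the stronger of the two measured members: in an assay on isolated protein for inhibition of Aromatase (Homo sapiens), read by fluorescence, with a stated time of 30 min (a higher number here means a weaker inhibitor, a lower number a stronger inhibitor), compound 1 gives 48.9 nM, the lowest number in the set. Compound 2 `CCC(CC)=C(c1ccc(O)cc1)c1ccc(OCCN)cc1` sits far away; in this assay compound 2 gives 1320 nM, a gap well beyond the scatter. The untested compound 3 `C/C(=C(/c1ccc(O)cc1)c1ccc(OCCN)cc1)c1ccccc1` differs from compound 1 in a single place: hydrogen in place of cyano on a saturated chain carbon bound to a double-bonded chain carbon. Among the measured compounds shown here, no measured pair in this set isolates that change, so the direction is read from the position of compound 1 alone. The expectation is a weakening, a moderate step in this assay from compound 1 to compound 3 of a 4.1-fold higher number from compound 1 to compound 3 (0.61 log units; beyond the scatter), because compound 1 holds the best value at 48.9 nM and removing a group rarely improves on it. Compound 3 is therefore estimated at 200 nM, with a range of 60 nM to 700 nM.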

Compound 3, half-maximal inhibitory concentration: 337 nM
Estimate against measurement, compound 3: 1.7-fold (0.23 log units) below; the measured number falls inside the stated range.
By their numbers in this assay, from the lowest: compound 1; then compound 3; then compound 2.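

In this assay, among these compounds, cutting cyanomethyl to methyl on the shared core gives a 6.9-fold higher number from compound 1 to compound 3 (0.84 log units; beyond the scatter), the first reading in this set that isolates this position. The change on the saturated chain carbon bound to a double-bonded chain carbon therefore registers clearly in the read-out, with the cyano-bearing compound 1 holding the lower number. No measurement on hand accounts for the size or direction of this step.

Compound 1 gives 48.9 nM. Among the compounds shown here, the single pair does not separate the nitrile itself from the added chain length, so an ethyl group or a carboxylic acid at this place could either approach that number or fall short of it. On these data alone, whether the step carries over to other cores also remains open, as this reading rests on one pair.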